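A few compounds are considered here, and "the series" means these few. Any claim that something is new, unique, unknown or untested is made for them only; others in the source may bear on it.

Of the compounds shown here, three that share one core have been tested in an assay on CHO-K1 cells for antagonist activity at adenosine receptor A1 (Homo sapiens), read by a beta-galactosidase reporter, with stated times of 15 min and 6 h; a higher number here means a weaker inhibitor, a lower number a stronger inhibitor. Compound 1 `Nc1nc(-c2ccco2)nc2sc(CNC3CCCCC3)cc12` gives 2480 nM in this assay. Compound 2 `Cc1ccc(-c2nc(N)c3cc(CN4CCCCC4)sc3n2)o1` gives 610 nM in this assay. Compound 3 `CCc1ccc(-c2nc(N)c3cc(CN4[C@H](C)CCC[C@@H]4C)sc3n2)o1` gives 190 nM in this assay, the lowest number of the three, and thus the strongest inhibitor among them: its gap to compound 2 lies beyond the scatter, and its gap to compound 1 lies further beyond it. The three differ from one another in more than one place at once, so no single structural change can be read from these values alone.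

Compound 4 `CC(C)c1ccc(-c2nc(N)c3cc(CN4[C@H](C)CCC[C@@H]4C)sc3n2)o1` is not yet measured. It differs from compound 3 by methyl in place of hydrogen on a saturated chain carbon bound to an aromatic carbon and a saturated chain carbon. Within the data shown here, no pair of measured compounds differs in exactly this place, so the size of this step is not known from the data. Given that the change is one carbon added to a short chain on the furan ring, the step from compound 3 to compound 4 in this assay is expected to be small, a 1.1-fold lower number from compound 3 to compound 4 (0.05 log units; within the scatter), at most near the edge of the scatter and with no firm direction. Compound 4 is therefore estimated to give 170 nM in this assay, with a likely range from 60 nM to 500 nM.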

Compound 4, inhibition constant: 140 nM
Beside the measured number, compound 4's estimate is 1.2-fold (0.08 log units) above it; measured number inside the range.
By their numbers in this assay, from the lowest: compounds 4 and 3 (each within the scatter of the next); then compound 2; then compound 1.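

Among these compounds, compound 3 and compound 4 differ in one place only, which makes this the first change in the set that can be read on its own: in this assay, going from 5-ethylfuran-2-yl to 5-isopropylfuran-2-yl gives a 1.4-fold lower number from compound 3 to compound 4 (0.13 log units; within the scatter). At this saturated chain carbon, then, methyl in place of hydrogen leaves the two compounds level within the usual scatter of repeated measurements, and this assay does not tell the ethyl and isopropyl groups apart. No measurement is at hand that would explain this result.

This single step sets no trend, and it leaves open how a tert-butyl group, a cyclopropyl ring, a longer chain or an amine on the chain would read at the same place. The earlier compounds shown here differ from one another in more than one place, and their steps cannot be read, leaving the separate contributions of the other parts of these molecules unknown.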